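Removing the neutral sugar from a highly soluble macrolide

The compounds below may be only part of what the source reports. "The series", "measured", "known", "first", "only" and "open" are said of these compounds alone.

Compound 1 `CC[C@H]1OC(=O)[C@H](C)[C@@H](O[C@H]2C[C@@](C)(OC)[C@@H](O)[C@H](C)O2)[C@H](C)[C@@H](O[C@@H]2O[C@H](C)C[C@H](N(C)C)[C@H]2OCCCNc2ccnc3cc(Cl)ccc23)[C@](C)(O)C[C@@H](C)CN(C)[C@H](C)[C@@H](O)[C@]1(C)O` is one of two measured compounds in this set. In a physicochemical assay for solubility, at pH 4 (a lower number here means a less soluble compound, a higher number a more soluble compound), compound 1 gives > 10000 ug/mL, which is a limit of the assay rather than a number. Compound 2 `CC[C@H]1OC(=O)[C@H](C)[C@@H](O[C@H]2C[C@@](C)(OC)[C@@H](O)[C@H](C)O2)[C@H](C)[C@@H](O[C@@H]2O[C@H](C)C[C@H](N(C)C)[C@H]2OCCCNc2ccnc3ccccc23)[C@](C)(O)C[C@@H](C)CN(C)[C@H](C)[C@@H](O)[C@]1(C)O` differs from it by a hydrogen in place of chloro on an aromatic carbon. In this assay compound 2 gives > 10000 ug/mL, again a limit. For the measured compounds named here, the step that the two limits leave unreadable from compound 1 to compound 2 therefore cannot be read, and the only evidence on the measured pair is the limit of > 10000 ug/mL in this assay, at which 2 of the 2 values shown sit. Compound 3 `CC[C@H]1OC(=O)[C@H](C)[C@@H](O)[C@H](C)[C@@H](O[C@@H]2O[C@H](C)C[C@H](N(C)C)[C@H]2OCCCNc2ccnc3cc(Cl)ccc23)[C@](C)(O)C[C@@H](C)CN(C)[C@H](C)[C@@H](O)[C@]1(C)O` differs from compound 1 by hydrogen in place of 5-hydroxy-4-methoxy-4,6-dimethyloxan-2-yl on an oxygen on a saturated carbon. Going by the values given here, no measured step bears on this particular change, and the one step that was measured is unreadable, so no size can be carried over from the data. The expectation for compound 3 is that the step of a number no higher from compound 1 to compound 3 (the limit leaves the size open) leaves it near the same limit as compound 1, with no readable change in direction. The estimate for compound 3 in this assay is 10000 ug/mL, with a range from 3000 ug/mL to 10000 ug/mL.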

Compound 3, solubility: > 10000 ug/mL
Compound 3: only a limit was reported (the forecaster's own chance of this, stated with the estimate: 75%); the middle value lies on the limit itself.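

In this assay compound 3 gives > 10000 ug/mL, which is a limit of the assay and not a number. Compound 1 also sits at a limit, so no step can be read between compound 1 and compound 3: the limit of > 10000 ug/mL in this assay, at which 3 of the 3 values shown sit.

The compounds shown leave open where the solubility of each lies beyond that limit, and so whether exchanging the 5-hydroxy-4-methoxy-4,6-dimethyloxan-2-yl group or the chloro group for hydrogen changes it at all.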